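The compounds below may be only part of what the source reports. "The series", "measured", "known", "first", "only" and "open" are said of these compounds alone.

Compound 1 `COc1cccc(N2C(=O)COc3ccc(-c4cnc(Cl)c(NS(=O)(=O)c5ccc(F)cc5)c4)cc32)c1` carries a 3-methoxyphenyl on the ring amide nitrogen of the shared core. In a functional assay on HeLa cells (Homo sapiens) for antiproliferative activity, read by MTT assay, with a stated time of 72 h (on this read-out higher numbers stand for weaker inhibition and lower numbers for stronger inhibition), compound 1 gives > 40000 nM, which is a limit of the assay. Compound 2 `O=C1COc2ccc(-c3cnc(Cl)c(NS(=O)(=O)c4ccc(F)cc4)c3)cc2N1` bears hydrogen there instead, the change being (hydrogen in place of 3-methoxyphenyl on an amide-type nitrogen in a ring), and in this assay compound 2 gives 15600 nM. That step is an at least 2.5-fold lower number from compound 1 to compound 2 (0.40 log units; beyond the scatter), though it rests on one limit, as shown by the limit of > 40000 nM in this assay, at which 2 of the 3 values shown sit. Compound 3 `COc1cccc(N2C(=O)COc3ccc(-c4ccc(O)cc4)cc32)c1` keeps the 3-methoxyphenyl on a different core; how its core differs from that of compound 1 is not broken down here. In this assay compound 3 gives > 40000 nM, a limit. Compound 4 `O=C1COc2ccc(-c3ccc(O)cc3)cc2N1` applies the same change, (hydrogen in place of 3-methoxyphenyl on an amide-type nitrogen in a ring). He expects a step of an at least 1.1-fold lower number from compound 3 to compound 4 (0.05 log units; that floor lies within the scatter) for compound 4, resting on the step from compound 1 to compound 2 an at least 2.5-fold lower number from compound 1 to compound 2 (0.40 log units; beyond the scatter). He estimates compound 4 at 35000 nM, between 12000 nM and 100000 nM.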

Compound 4, half-maximal inhibitory concentration: > 40000 nM
Compound 4: no number, only a limit; the forecaster's own chance of this, stated with the estimate: 60%; middle value at least 1.1-fold (0.05 log units) from the limit.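

Compound 3 and compound 4 both stand at a limit, so no step can be read between them: the limit of > 40000 nM in this assay, at which 3 of the 4 values shown sit.

The compounds shown leave open whether hydrogen in place of 3-methoxyphenyl changes antiproliferative activity on the core of compound 3.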